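The source may report more compounds than this note shows. Statements on the series, on what has been measured and on what is new or still open speak of the compounds shown alone.

Measured compounds:
compound 1 `Cc1ccc(S(=O)(=O)/N=C(/CCNC2=CC(=O)c3ccccc3C2=O)Nc2cccc(C(F)(F)F)c2)cc1` — 89100 nM
compound 2 `COc1cc(N/C(CCNC2=CC(=O)c3ccccc3C2=O)=N\S(=O)(=O)c2ccc(C)cc2)cc(OC)c1OC` — 3050 nM
compound 3 `Cc1ccc(S(=O)(=O)/N=C(/CCNC2=CC(=O)c3ccccc3C2=O)Nc2cc(F)c(F)c(F)c2)cc1` — 6610 nM

In a functional assay on MCF7 cells (Homo sapiens) for cytotoxicity, read by MTT assay, with a stated time of 48 h (a lower number here means a stronger inhibitor, a higher number a weaker inhibitor), compound 3 holds the second highest of the three numbers; the step of a 2.2-fold higher number from compound 2 to compound 3 (0.34 log units; beyond the scatter) is modest, the step of a 13-fold lower number from compound 1 to compound 3 (1.13 log units; beyond the scatter) is large, so the group on the amine nitrogen moves the number over a wide span. Compound 4 `Cc1ccc(S(=O)(=O)/N=C(/CCNC2=CC(=O)c3ccccc3C2=O)NC(C)C)cc1` differs from compound 3 by isopropyl in place of 3,4,5-trifluorophenyl on an amine nitrogen. For the measured compounds named here, no measured step swaps an aryl group for an alkyl group at this nitrogen; the steps of a 29-fold lower number from compound 1 to compound 2 (1.47 log units; beyond the scatter) and a 13-fold lower number from compound 1 to compound 3 (1.13 log units; beyond the scatter) only show that this position is sensitive. A change beyond the scatter is therefore expected, most likely toward a higher number, with wide uncertainty. Compound 4 is estimated at 15000 nM, within 3000 nM to 60000 nM, an expected step of a 2.3-fold higher number from compound 3 to compound 4 (0.36 log units; beyond the scatter).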

Compound 4, half-maximal inhibitory concentration: 16500 nM
Compound 4: middle estimate off by 1.1-fold (0.04 log units), on the low side; measured number inside the range.
By their numbers in this assay, from the lowest: compound 2; then compound 3; then compound 4; then compound 1.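

In this assay, for the compounds shown here, isopropyl gives the first reading for an alkyl group on this amine nitrogen, and the direction of the change depends on which aryl group leaves: a 2.5-fold higher number from compound 3 to compound 4 (0.40 log units; beyond the scatter) and a 5.4-fold higher number from compound 2 to compound 4 (0.73 log units; beyond the scatter), but a 5.4-fold lower number from compound 1 to compound 4 (0.73 log units; beyond the scatter). An aryl ring is therefore not needed for a number within the span of the three aryl compounds, and 3-(trifluoromethyl)phenyl, not the alkyl group, remains the outlier on the high side. No measured property is available to explain these steps. Still open, on these data alone, is how a longer alkyl chain, a cyclohexyl ring or a chain ending in an amine would read at this nitrogen.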